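Benzyl-type swap on the shared core, compound 1 to compound 4

The source may report more compounds than this note shows. Statements on the series, on what has been measured and on what is new or still open speak of the compounds shown alone.

Three compounds of this series have been run in a functional assay on PC-9 cells (Homo sapiens) for inhibition, read by MTT assay, with a stated time of 72 h; on this read-out lower numbers stand for stronger inhibition and higher numbers for weaker inhibition. Compound 1 `Cc1cc(Nc2ccn(Cc3cccc4ccccc34)n2)n2nc(SCc3ccc(Br)cc3)nc2n1` gives 5660 nM there. Compound 3 `Cc1cc(Nc2cc(-c3ccc(Cl)cc3)[nH]n2)n2nc(SCc3ccc(Br)cc3)nc2n1` gives 4920 nM in this assay, and compound 2 `Cc1cc(Nc2cc(-c3ccccc3)[nH]n2)n2nc(SCc3ccc(Cl)cc3)nc2n1` gives 6710 nM; both of these numbers lie within the scatter of the number for compound 1, so the three compounds cannot be told apart on potency, and none of them can be called the strongest or the weakest. Within the data shown here, the set therefore gives no measured step at all, and no guide to how changes on the benzyl-type arm are felt.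

Compound 4 `COc1ccc(Cn2ccc(Nc3cc(C)nc4nc(SCc5ccc(Br)cc5)nn34)n2)cc1` differs from compound 1 in just one place: 4-methoxyphenyl in place of naphthalen-1-yl on a saturated chain carbon bound to an aromatic nitrogen. Among the measured compounds shown here, neither group appears anywhere else among the measured compounds, so the change has no precedent here; the only evidence is that the three measured compounds, with rather different groups on their outer arms, all fall in a narrow band.

Compound 4 is therefore expected at 5000 nM, with a range of 2000 nM to 13000 nM. The expected step of a 1.1-fold lower number from compound 1 to compound 4 (0.05 log units; within the scatter) is no more than the scatter, in no particular direction.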

Compound 4, half-maximal inhibitory concentration: > 50000 nM
Compound 4: only a limit was reported; the forecaster's own chance of this, stated with the estimate: 5%; middle value at least 10-fold (1.00 log units) away from the limit.
By their numbers in this assay, from the lowest: compounds 3, 1 and 2 (each within the scatter of the next). At a limit, above all of these: compound 4.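

In this assay compound 4 gives > 50000 nM, which is a limit of the assay and not a number. Taking 4-methoxyphenyl in place of naphthalen-1-yl on a saturated chain carbon bound to an aromatic nitrogen gives the first measured step in the series, an at least 8.8-fold higher number from compound 1 to compound 4 (0.94 log units; beyond the scatter), so this arm is not indifferent to change, and the narrow band shared by compounds 1, 2 and 3 does not extend to every group placed here. The size of this step is bounded on one side only, and it rests on a single pair of compounds: the limit of > 50000 nM in this assay, at which 1 of the 4 values shown sits.

The pair leaves open whether the loss in inhibition goes with the change from two aromatic rings to one or with the entry of the methoxy oxygen, as both changes arrive together in compound 4. A plain benzyl group on the same chain carbon would separate these two changes, while a hydroxyl or an amine in place of the methoxy group would show whether the outcome depends on that particular substituent.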